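The source may hold more compounds than are shown below. What is called first, only, known or untested is meant among the compounds shown, and "the series" means these compounds.

Compound 1 `NC(=O)OC(CCN1CCN(c2ccccc2)CC1)c1ccc([N+](=O)[O-])cc1`: 91.2%
Compound 2 `COc1ccc(C(CCN2CCN(c3ccc(OC)cc3)CC2)OC(N)=O)cc1`: 53%

In a functional assay on the whole organism for inhibition, with Mus musculus as the target, in the writhing test, with a stated time of 1 h, at a dose of 10 mg/kg by the oral route (on this read-out lower numbers stand for less inhibition and higher numbers for more inhibition at the one dose given (going by the name of the read-out)), compound 1 gives 91.2% while compound 2 gives 53%, so compound 2 stands lowest of the two numbers, a gap beyond the usual scatter. Compound 3 `COc1ccc(C(CCN2CCN(c3ccccc3)CC2)OC(N)=O)cc1` is the next step from compound 2. The change is hydrogen in place of methoxy on an aromatic carbon. Among the measured compounds shown here, no measured pair shows this change alone, so its size here is uncertain. Compound 1, which also carries a plain phenyl on the piperazine, gives the higher number, but it differs in a second place as well. A moderate rise is expected from compound 2 to compound 3, a number 17 percentage points higher from compound 2 to compound 3 (beyond the scatter). Compound 3 is therefore estimated at 70%, within a range from 45% to 92% in this assay.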

Compound 3, a percentage reported as inhibition, in the whole organism at one dose (the size of the read-out at that dose, not a potency): 43%
Estimate against measurement, compound 3: 27 percentage points above; measured number below the stated range.
By their numbers in this assay, from the lowest: compounds 3 and 2 (each within the scatter of the next); then compound 1.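

In this assay, replacing 4-methoxyphenyl with phenyl gives a number 10 percentage points lower from compound 2 to compound 3 (within the scatter), so the read-out does not separate these two compounds and this methoxy shows no clear effect at this dose. The change on the other aromatic ring matters far more: methoxy in place of nitro gives a number 48.2 percentage points lower from compound 1 to compound 3 (beyond the scatter), a large step that stands beyond the scatter. Nothing available explains either step. Still open, from the compounds shown here alone, is how a nitrile or an amine would read at the place held by nitro, and whether any other group there keeps the high number of compound 1.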